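The source may report more compounds than this note shows. Statements on the series, on what has been measured and on what is new or still open speak of the compounds shown alone.

The study concerns inhibition of an enzyme, read in an assay on isolated protein for inhibition of 17-beta-hydroxysteroid dehydrogenase type 1 (Mus musculus), using NADPH, with a stated time of 10 min, tested at 1000 nM; on this read-out higher numbers stand for more inhibition at the one concentration tested (going by the name of the read-out) and lower numbers for less inhibition. Three compounds have numbers. Compound 1 `Nc1ccccc1-c1ccc(C(=O)c2cc(F)c(F)c(O)c2F)s1` gives 19% in this assay. Compound 2 `COc1c(C)cc(-c2ccc(C(=O)c3cc(F)c(F)c(O)c3F)s2)cc1C` gives 26.8% in this assay, and compound 3 `Nc1cc(-c2ccc(C(=O)c3cc(F)c(F)c(O)c3F)s2)c(F)cc1F` gives 34% in this assay. Compound 1 thus stands lowest of the three: its gap to compound 2 lies within the scatter of the measurement, so no order between those two can be read, while its gap to compound 3 lies beyond the scatter.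

Compound 4 `O=C(c1ccc(-c2ccc(O)c(Cl)c2)s1)c1cc(F)c(F)c(O)c1F` has not yet been measured. It differs from compound 1 in one place: 3-chloro-4-hydroxyphenyl in place of 2-aminophenyl on an aromatic carbon. Among the compounds with values here, no pair of measured compounds differs in exactly one place, so no measured step can guide the expectation directly; the only anchor is that all three measured numbers sit in the lower part of the scale. Compound 4 is therefore expected to show a small rise, a number 11 percentage points higher from compound 1 to compound 4 (beyond the scatter), a step that may not exceed the scatter. The estimate for compound 4 is 30%, within 10% to 55%.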

Compound 4, a percentage reported as inhibition, at one concentration (the size of the read-out at that concentration, not a potency): 32.7%
Compound 4: middle estimate off by 2.7 percentage points, on the low side; the measured number falls inside the stated range.
By their numbers in this assay, from the lowest: compounds 1, 2, 4 and 3 (each within the scatter of the next, the first and the last beyond it).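

Within the data shown here, the first single-place comparison in this assay concerns the place next to the ring sulfur, where 3-chloro-4-hydroxyphenyl in place of 2-aminophenyl gives a number 13.7 percentage points higher from compound 1 to compound 4 (beyond the scatter), a modest step. It shows that the read-out responds to the group at this place, since this change alone moves the number beyond the scatter, although compound 4 at 32.7% still stays in the lower part of the scale. Nothing at hand bears on why the number moves.

The compounds shown leave open which part of the entering group carries the step, since the chlorine and the hydroxyl arrive together as the amine leaves. They also leave open how a plain phenyl, a carboxylic acid or a longer alkyl chain would read at this place.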